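This account rests on a few compounds, and the source may have more. Where it says the series, first, only, none or still open, it means among the compounds named here.

Compound 1 `CN(C)CCCCCn1c2c(c3ccccc31)C(=O)c1c[n+]([O-])c3ccccc3c1C2=O`: 210 nM
Compound 2 `CN1CCN(CCCCn2c3c(c4ccccc42)C(=O)c2c[n+]([O-])c4ccccc4c2C3=O)CC1`: 90 nM
Compound 3 `CN(C)CCCCn1c2c(c3ccccc31)C(=O)c1c[n+]([O-])c3ccccc3c1C2=O`: 310 nM

In a functional assay on A549 cells (Homo sapiens) for cytotoxicity, read by MTT assay, with a stated time of 72 h (on this read-out lower numbers stand for stronger inhibition and higher numbers for weaker inhibition), compound 3 gives 310 nM, the highest number of the set, though a 1.5-fold higher number from compound 1 to compound 3 (0.17 log units; within the scatter) and so cannot be separated from compound 1. Compound 2 is clearly lower, with a 3.4-fold higher number from compound 2 to compound 3 (0.54 log units; beyond the scatter).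

Compound 4 `O=C1c2c[n+]([O-])c3ccccc3c2C(=O)c2c1c1ccccc1n2CCCN1CCC(O)CC1` is unmeasured. It differs from compound 3 as follows: 4-hydroxypiperidin-1-yl in place of (dimethylamino)methyl on a saturated chain carbon, three bonds along the chain from an aromatic nitrogen. Read one bond further out, 4-(dimethylamino)butyl becomes 3-(4-hydroxypiperidin-1-yl)propyl.

The chain change alone mattered little in the step of a 1.5-fold higher number from compound 1 to compound 3 (0.17 log units; within the scatter). Within the data shown here, a ring on the chain mattered more in the step of a 2.3-fold lower number from compound 1 to compound 2 (0.37 log units; beyond the scatter), although that ring differs from the one in compound 4. A modest drop in this assay is therefore expected, with an estimated 1.8-fold lower number from compound 3 to compound 4 (0.26 log units; within the scatter).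

Compound 4 is expected at 170 nM, with an estimated range of 65 nM to 430 nM.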

Compound 4, half-maximal inhibitory concentration: 350 nM
The estimate for compound 4 lay 2.1-fold (0.31 log units) below the measured number, and the stated range covers the measured number.
By their numbers in this assay, from the lowest: compound 2; then compounds 1, 3 and 4 (each within the scatter of the next).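

A ring at the end of the chain does not by itself lower the number in this assay. Replacing 4-(dimethylamino)butyl with 3-(4-hydroxypiperidin-1-yl)propyl gives a 1.1-fold higher number from compound 3 to compound 4 (0.05 log units; within the scatter), and the comparison with the longer chain gives a 1.7-fold higher number from compound 1 to compound 4 (0.22 log units; within the scatter), whereas the 4-methylpiperazin-1-yl compound stands apart, with a 3.9-fold higher number from compound 2 to compound 4 (0.59 log units; beyond the scatter), so the particular ring and chain matter, not a ring as such. No measurement here explains this.

The compounds shown leave open whether ring or chain length drives that gap, which 4-methylpiperazin-1-yl on a propyl chain could help separate. A plain piperidine at the chain end would test the hydroxyl group.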